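Notes on the aromatic substituent step from compound 2

This account rests on a few compounds, and the source may have more. Where it says the series, first, only, none or still open, it means among the compounds named here.

In a functional assay on HepG2 cells (Homo sapiens) for antiproliferative activity, read by MTT assay, with a stated time of 72 h (a lower number here means a stronger inhibitor, a higher number a weaker inhibitor), compound 1 (`Cn1cc(-c2nn(Cc3ccc(C(=O)N4CCCCC4)cc3)c(=O)c3ccccc23)cn1`) gives 73100 nM and compound 2 (`CN1CCC(NC(=O)c2ccc(Cn3nc(-c4cnn(C)c4)c4ccccc4c3=O)cc2)CC1`) gives 47300 nM. These two numbers lie within the scatter of each other, so compound 2 stands level with compound 1 and no order can be drawn between them.

The next compound is compound 3 (`Cc1noc(C)c1-c1nn(Cc2ccc(C(=O)NC3CCN(C)CC3)cc2)c(=O)c2ccccc12`), which keeps the (1-methylpiperidin-4-yl)amino group on the carbonyl carbon. Its difference from compound 2 lies on an aromatic carbon of the shared core: 3,5-dimethyl-1,2-oxazol-4-yl in place of 1-methyl-1H-pyrazol-4-yl on an aromatic carbon.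

Among the measured compounds shown here, only one measured step is available, a 1.5-fold lower number from compound 1 to compound 2 (0.19 log units; within the scatter). It lies within the scatter and sits on the carbonyl carbon, not at the place that now changes. For the measured compounds named here, no measured step covers this aromatic carbon, so the data give only indirect guidance and no direction. On this limited basis, no step beyond the scatter is expected in this assay, with a wide margin on either side. The estimated step is a 1.2-fold lower number from compound 2 to compound 3 (0.07 log units; within the scatter). The expected value for compound 3 is 40000 nM, with an estimated range of 12000 nM to 100000 nM.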

Compound 3, half-maximal inhibitory concentration: > 100000 nM
Compound 3 was reported as a limit (the forecaster's own chance of this, stated with the estimate: 15%); middle value at least 2.5-fold (0.39 log units) from the limit.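

In this assay, among the compounds shown here, the aromatic carbon of the shared core is the first place where a single change gives a step beyond the scatter: 3,5-dimethyl-1,2-oxazol-4-yl in place of 1-methyl-1H-pyrazol-4-yl gives an at least 2.1-fold higher number from compound 2 to compound 3 (0.32 log units; beyond the scatter). The earlier change on the carbonyl carbon, a 1.5-fold lower number from compound 1 to compound 2 (0.19 log units; within the scatter), gave no such separation, so among the compounds shown only this aromatic carbon has a step with a readable direction. The figure for compound 3 is a limit of the assay and not a number, so this step has a direction and no upper size, and compound 3 sits at the end of the measurable range: the limit of > 100000 nM in this assay, at which 1 of the 3 values shown sits.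

Compound 2 and compound 3 differ both in the ring hetero atoms and in the methyl groups on the ring, and the compounds shown do not separate these two parts of the change. Going by these compounds, a 3,5-dimethyl-1H-pyrazol-4-yl group or a 1,2-oxazol-4-yl group without methyl groups on this aromatic carbon would tell them apart, and whether any group here gives a lower number than compound 2 remains open.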